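Isopentyloxy in place of (butylcarbonyl)oxy on the shared core

The compounds below may be only part of what the source reports. "The series", "measured", "known", "first", "only" and "open" are said of these compounds alone.

Values so far in a functional assay on A549 cells (Homo sapiens) for cytotoxicity, with a stated time of 48 h (on this read-out higher numbers stand for weaker inhibition and lower numbers for stronger inhibition), for two compounds:
- compound 1 `CCCC(=O)Oc1ccc2oc(/C=C/[S+](C)[O-])cc(=O)c2c1` gives 2200 nM on this read-out
- compound 2 `CCCCC(=O)Oc1ccc2oc(/C=C/[S+](C)[O-])cc(=O)c2c1` gives 2400 nM on this read-out

In this assay compound 2 stands at 2400 nM and lies within the scatter of compound 1, so the pair cannot be ordered. The next compound is compound 3 `CC(C)CCOc1ccc2oc(/C=C/[S+](C)[O-])cc(=O)c2c1`, which carries isopentyl in place of butylcarbonyl on an oxygen on an aromatic ring. Among the measured compounds shown here, the only measured step is a 1.1-fold higher number from compound 1 to compound 2 (0.04 log units; within the scatter) for methyl in place of hydrogen on a saturated chain carbon. For the measured compounds named here, that step keeps the carbonyl, and no measured compound lacks it, so the step is only a weak guide to this change. On this thin evidence, no shift beyond the scatter is expected in this assay and the range is kept wide. The expected step is a 1.3-fold higher number from compound 2 to compound 3 (0.10 log units; within the scatter) on this estimate. For compound 3 the estimated value is 3000 nM with an expected range from 1200 nM to 7500 nM in this read-out.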

Compound 3, half-maximal inhibitory concentration: 1000 nM
Compound 3: middle estimate off by 3.0-fold (0.48 log units), on the high side; measured number outside the range, below it.
By their numbers in this assay, from the lowest: compound 3; then compounds 1 and 2 (each within the scatter of the next).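

Compounds 1 and 2 showed only that one added methyl on the chain of the carbonyl-bearing group gives no readable change in this assay, so they said nothing about replacing that group. On the oxygen on an aromatic ring, the exchange of butylcarbonyl for isopentyl gives a 2.4-fold lower number from compound 2 to compound 3 (0.38 log units; beyond the scatter), and the exchange of propylcarbonyl for isopentyl gives a 2.2-fold lower number from compound 1 to compound 3 (0.34 log units; beyond the scatter); both steps lie beyond the scatter but are modest, and the lower number means stronger inhibition for compound 3 against either carbonyl-bearing partner. This position therefore responds to an exchange that removes the carbonyl and leaves a saturated branched chain, although no measurement at hand gives a reason for the shift.

The change removes the carbonyl and introduces branching together, so the compounds shown cannot assign the shift to either one, and a straight pentyl group on the same oxygen would separate the two. Also open, from the compounds shown here alone, is how this position reads with a much shorter group such as methyl, or with a chain ending in an amine or a carboxylic acid.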